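Amide to urea on the chlorinated trifluoromethylphenyl arm

The source may hold more compounds than are shown below. What is called first, only, known or untested is meant among the compounds shown, and "the series" means these compounds.

Compound 3 `COc1cc(-c2nn(-c3cccc(NC(=O)c4ccc(Cl)c(C(F)(F)F)c4)c3)cc2-c2ccncc2)ccc1Cl` bears a 4-chloro-3-(trifluoromethyl)phenyl on the carbonyl carbon. In a functional assay on T47D cells (Homo sapiens) for inhibition, read by sulforhodamine B assay, with a stated time of 48 h (on this read-out higher numbers stand for lower toxicity in this test and lower numbers for higher toxicity in this test), compound 3 reaches only a limit of the assay, > 32500 nM. Compound 1 `COc1cc(-c2nn(-c3cccc(NC(=O)c4cccc(C(F)(F)F)c4)c3)cc2-c2ccncc2)ccc1Cl` likewise reaches only a limit in this assay, > 50000 nM. Compound 2 `COc1cc(-c2nn(-c3cccc(NC(=O)Nc4cccc(C(F)(F)F)c4)c3)cc2-c2ccncc2)ccc1Cl` gives 50000 nM in this assay. Across the series, the amide-to-urea exchange gave a number no higher from compound 1 to compound 2 (the limit leaves the size open), while the chloro addition a step that the two limits leave unreadable from compound 1 to compound 3 and the cross comparison a step that the limit leaves unreadable from compound 2 to compound 3 remain unreadable because of the limits the limit of > 32500 nM in this assay, at which 1 of the 3 values shown sits, and (the limit of > 50000 nM in this assay, at which 1 of the 3 values shown sits). Compound 3 thus stands at the inactive end of what is shown, alongside compound 1.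

Compound 4 `COc1cc(-c2nn(-c3cccc(NC(=O)Nc4ccc(Cl)c(C(F)(F)F)c4)c3)cc2-c2ccncc2)ccc1Cl` differs from compound 3 by (4-chloro-3-(trifluoromethyl)phenyl)amino in place of 4-chloro-3-(trifluoromethyl)phenyl on a carbonyl carbon. Going by the values given here, the one measured step of the same kind, from compound 1 to compound 2, stayed at or near the limit, so no step beyond the scatter is expected here, and any movement would be toward a number rather than a limit. Compound 4 is therefore estimated at 50000 nM in this assay, with a range from 25000 nM to 100000 nM, the expected step being a step that the limit leaves unreadable from compound 3 to compound 4, within the scatter.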

Compound 4, concentration lethal to 50% of the cells: > 32500 nM
Compound 4: a limit, no number; the forecaster's own chance of this, stated with the estimate: 60%; the middle value is on the limit's open side.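

In this assay, going by these compounds alone, compound 4 gives only a limit, > 32500 nM, so no step to compound 4 from compound 1, compound 2 or compound 3 can be read. The compounds shown leave open whether the amide-to-urea exchange or the chloro addition changes this read-out at all.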